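The compounds below may be only part of what the source reports. "The series", "measured", "known", "first", "only" and "open" are said of these compounds alone.

Working notes on a small series built on one shared core. Compound 1 `CC1(C)C(c2ccc(Br)cc2)=NN(C(=O)COc2cccc3cccnc23)C1c1ccccc1` and compound 2 `CC1(C)C(c2ccc(Cl)cc2)=NN(C(=O)COc2cccc3cccnc23)C1c1ccccc1` each carry a halogen. In an ADME assay on MCF7 cells (Homo sapiens) for cytotoxicity, read by MTT assay, with a stated time of 48 h (on this read-out higher numbers stand for weaker inhibition and lower numbers for stronger inhibition), compound 1 returns "not determined" (no result reported). Compound 2 likewise returns "not determined" (no result reported). Among the compounds with values here, compound 3 `CC1(C)C(c2ccccc2)=NN(C(=O)COc2cccc3cccnc23)C1c1ccccc1` is the only member with a reported reading in this assay, and that reading, > 100000 nM, is a limit of the assay rather than a number (the limit of > 100000 nM in this assay, at which 1 of the 3 values shown sits). Within the data shown here, no step between measured compounds is available, so compound 3 stands alone at that limit. Compound 4 `CC1(C)C(c2ccccc2)=NN(C(=O)COc2cccc3cccnc23)C1c1cccc(Cl)c1` differs from compound 3 by chloro in place of hydrogen on an aromatic carbon. Given that compound 3 sits at the limit > 100000 nM, the step from compound 3 to compound 4 is expected to be an at least 1.2-fold lower number from compound 3 to compound 4 (0.09 log units; that floor lies within the scatter), at most a modest move toward stronger inhibition and possibly none beyond the scatter. Compound 4 is accordingly estimated at 80000 nM, within 20000 nM to 200000 nM, with a real chance that only a limit is reported again.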

Compound 4, half-maximal inhibitory concentration: > 100000 nM
Compound 4: only a limit was reported; the forecaster's own chance of this, stated with the estimate: 55%; middle value at least 1.2-fold (0.09 log units) away from the limit.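

The step between compound 3 and compound 4 cannot be read, because both readings are limits of the assay and not numbers: the limit of > 100000 nM in this assay, at which 2 of the 4 values shown sit.

The compounds shown leave open whether chloro in place of hydrogen on an aromatic carbon changes the reading in this assay at all.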